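The source may report more compounds than this note shows. Statements on the series, on what has been measured and on what is new or still open speak of the compounds shown alone.

Two compounds of this series have measured numbers. In a functional assay on CHO-K1 cells for antagonist activity at melanin-concentrating hormone receptor 1 (Homo sapiens), read by inositol phosphate accumulation, with stated times of 10 min and 45 min (a lower number here means a stronger inhibitor, a higher number a weaker inhibitor), compound 1 `Cc1nc(N(C)C2CCCC2)nc2ccc(NC(=O)/C=C/c3ccc(Cl)cc3)cc12` gives 57 nM. In this assay compound 2 `COc1ccc(/C=C/C(=O)Nc2ccc3nc(N4CCC(O)(C5CC5)CC4)nc(C)c3c2)cc1` gives 59 nM; the two numbers lie within the scatter of each other, so on this read-out the two compounds cannot be told apart. Compound 3 `Cc1nc(N2CCC(O)CC2)nc2ccc(NC(=O)/C=C/c3ccc(Cl)cc3)cc12` has not yet been measured in this assay. It differs from compound 1 in one place: 4-hydroxypiperidin-1-yl in place of cyclopentyl(methyl)amino on an aromatic carbon. For the measured compounds named here, no pair of measured compounds differs only at this aromatic carbon, so no measured step fixes the size of such a change. Compound 2, which bears a different ring amine on the same aromatic carbon of the shared core, gives 59 nM, which suggests that variation of the amine there need not move the number much. For compound 3 the expected step is a 1.1-fold higher number from compound 1 to compound 3 (0.06 log units; within the scatter), not beyond the scatter. Compound 3 is therefore estimated at 65 nM, with a range from 20 nM to 220 nM.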

Compound 3, half-maximal inhibitory concentration: 73 nM
The estimate for compound 3 lay 1.1-fold (0.05 log units) below the measured number, within the range that was stated.
By their numbers in this assay, from the lowest: compounds 1, 2 and 3 (each within the scatter of the next).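

In this assay, for the compounds shown here, a 1.3-fold higher number from compound 1 to compound 3 (0.11 log units; within the scatter) is the first measured step at this aromatic carbon, and it lies within the scatter, so the two compounds cannot be told apart on this read-out. With the rest of compound 1 held fixed, the one-place exchange of cyclopentyl(methyl)amino for 4-hydroxypiperidin-1-yl replaces a five-membered ring of carbon only with a six-membered ring holding a hetero atom, and adds a hydrogen-bond donor, without a step beyond the scatter. Nothing on hand gives a reason for this outcome.

Going by these compounds alone, this single step covers only two ring-bearing amines, so it leaves open whether an open-chain group such as dimethylamino, an unsubstituted amine or a piperidine carrying a carboxylic acid would fit the same picture. Also open, going by these compounds, is whether the step would keep its size with a different group at the far end of the amide.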